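From 2,4-dichlorobenzyl to 2-chlorobenzyl: notes on compound 4

A few compounds are considered here, and "the series" means these few. Any claim that something is new, unique, unknown or untested is made for them only; others in the source may bear on it.

Measured in a functional assay on DU-145 cells (Homo sapiens) for inhibition, read by trypan blue exclusion, with a stated time of 96 h; a lower number here means a stronger inhibitor of growth, a higher number a weaker inhibitor of growth:
- compound 1 `O=C(O)c1ccc(C(=O)/C(=C\c2ccc(F)c([N+](=O)[O-])c2)SCc2ccc(Cl)cc2Cl)cc1`: 1000 nM
- compound 2 `O=C(/C(=C\c1ccc(OCc2ccccc2)cc1)SCc1cccc(Cl)c1)c1ccc(Br)cc1`: 1000 nM
- compound 3 `O=C(O)c1ccc(C(=O)/C(=C\c2ccc(Br)c([N+](=O)[O-])c2)SCc2ccc(Cl)cc2Cl)cc1`: 1000 nM

In this assay compound 1 stands level with compound 2 and compound 3, and none of the three separates from the others.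

Compound 4 `O=C(O)c1ccc(C(=O)/C(=C\c2ccc(F)c([N+](=O)[O-])c2)SCc2ccccc2Cl)cc1` differs from compound 1 by hydrogen in place of chloro on an aromatic carbon, which reads as 2,4-dichlorobenzyl to 2-chlorobenzyl. Among the compounds with values here, only one measured step bears on this change, and it does so indirectly: no change at the digits printed from compound 1 to compound 3 (within the scatter), with bromo in place of fluoro on an aromatic carbon. That step leaves the 2,4-dichlorobenzyl group untouched. Within the data shown here, no measured pair shows what the loss of this chloro does, so the range is kept wide.

On the evidence of no change at the digits printed from compound 1 to compound 3 (within the scatter), no step beyond the scatter is expected in this assay, and no direction is favoured. The expected outcome is no change at the digits printed from compound 1 to compound 4 (within the scatter). For compound 4 the estimate is 1000 nM, with an expected range of 400 nM to 2500 nM.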

Compound 4, concentration for 50% growth inhibition: 1000 nM
The estimate for compound 4 equals the measured number at the digits printed, and the stated range covers the measured number.
By their numbers in this assay, from the lowest: compounds 1, 2, 3 and 4 (each within the scatter of the next).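

In this assay, within the data shown here, the change from 2,4-dichlorobenzyl to 2-chlorobenzyl, hydrogen in place of chloro, gives no change at the digits printed from compound 1 to compound 4 (within the scatter), and this is the first measured pair to alter this group, since the earlier step, no change at the digits printed from compound 1 to compound 3 (within the scatter), left it untouched. On the core of compound 1, the chloro para to a large group can therefore be lost with the 2-chloro retained, without a step beyond the scatter in this assay. No measurement available here offers an explanation for this result.

As far as these compounds go, what an amine or a methoxy group would do at this same place on the ring remains open. Also open, from the compounds shown here alone, are the effect of losing the remaining chloro and whether the same change reads alike on the core of compound 3.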